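Ester chain variation in a cytotoxicity series

The compounds below may be only part of what the source reports. "The series", "measured", "known", "first", "only" and "open" are said of these compounds alone.

Compound 1 `CCCOC(=O)C(O)Cn1cnc2c(N)ncnc21`: in a functional assay on HeLa cells (Homo sapiens) for cytotoxicity (on this read-out higher numbers stand for lower toxicity in this test and lower numbers for higher toxicity in this test), compound 1 gives > 400 ug/mL, a limit of the assay.
Compound 2 `CC(C)COC(=O)C(O)Cn1cnc2c(N)ncnc21`: in this assay compound 2 gives > 400 ug/mL, a limit of the assay.

Compound 2 stands at the limit of > 400 ug/mL in this assay, at which 2 of the 2 values shown sit. Within the data shown here, the single measured step, a step that the two limits leave unreadable from compound 1 to compound 2, is the only one bearing on the next change, and it yields no size. Compound 3 `CCC(C)OC(=O)C(O)Cn1cnc2c(N)ncnc21` differs from compound 2 by sec-butyl in place of isobutyl on an oxygen next to a carbonyl group. No step beyond the scatter is expected for a step that the limit leaves unreadable from compound 2 to compound 3. Compound 3 is estimated at 500 ug/mL, with a range from 200 ug/mL to 1200 ug/mL, most likely reported again as a limit.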

Compound 3, minimum cytotoxic concentration: > 400 ug/mL
Compound 3 was reported as a limit (the forecaster's own chance of this, stated with the estimate: 85%); the middle value is on the limit's open side.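

Compound 3 gives > 400 ug/mL, again a limit of the assay, so its steps from compound 1 and compound 2 cannot be read. Any real difference among these three ester chains remains open.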